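A few compounds are considered here, and "the series" means these few. Any claim that something is new, unique, unknown or untested is made for them only; others in the source may bear on it.

Measured so far:
- compound 1, `Nc1cc2c(=O)c(C(=O)O)cn(C3CC3)c2cc1N1CCN(c2ccccn2)CC1`: 431000 nM
- compound 2, `Cn1cc(C(=O)O)c(=O)c2cc(N)c(N3CCN(c4ccccn4)CC3)cc21`: 54000 nM
- compound 3, `Nc1cc2c(=O)c(C(=O)O)cn(C3CC3)c2cc1N1CCN(c2nc3ccccc3s2)CC1`: 4500 nM

These three compounds were tested in an ADME assay on HFF cells (Homo sapiens) for cytotoxicity, read by MTT assay; on this read-out higher numbers stand for lower toxicity in this test and lower numbers for higher toxicity in this test. Among the three numbers, compound 1 stands highest; the nearest is compound 2, and the furthest is compound 3. The step from compound 1 to compound 2 replaces cyclopropyl with methyl on an aromatic nitrogen and gives an 8.0-fold lower number from compound 1 to compound 2 (0.90 log units; beyond the scatter). The step from compound 1 to compound 3 replaces pyridin-2-yl with 1,3-benzothiazol-2-yl on an amine nitrogen in a ring and gives a 96-fold lower number from compound 1 to compound 3 (1.98 log units; beyond the scatter).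

Compound 4, `CCOC(=O)c1cn(C2CC2)c2cc(N3CCN(c4ccccn4)CC3)c(N)cc2c1=O`, differs from compound 1 in a third place: ethyl in place of hydrogen on an oxygen next to a carbonyl group. Neither measured step touches this part of the molecule, so neither bears directly on the change; they show only that two alterations elsewhere on the shared core both lowered the number in this assay, one modestly and one by a large amount. Going by the values given here, for a change at the carboxy group there is no comparable pair. The expectation for compound 4 is therefore a step of roughly a 1.7-fold lower number from compound 1 to compound 4 (0.24 log units; within the scatter), leaning toward a somewhat lower number but with wide uncertainty. Compound 4 is estimated at 250000 nM, within a range from 60000 nM to 800000 nM.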

Compound 4, half-maximal cytotoxic concentration: 409000 nM
Compound 4: middle estimate off by 1.6-fold (0.21 log units), on the low side; the range from low to high includes it.
By their numbers in this assay, from the lowest: compound 3; then compound 2; then compounds 4 and 1 (each within the scatter of the next).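

In this assay the change from carboxy to ethoxycarbonyl gives a 1.1-fold lower number from compound 1 to compound 4 (0.02 log units; within the scatter) and so leaves the two compounds indistinguishable in this test, which means that the hydrogen on this oxygen can give way to ethyl with no visible effect on the number, at least with the cyclopropyl and pyridin-2-yl groups of compound 1 in place. This sets the position apart from the two places examined earlier, where an 8.0-fold lower number from compound 1 to compound 2 (0.90 log units; beyond the scatter) and a 96-fold lower number from compound 1 to compound 3 (1.98 log units; beyond the scatter) were both beyond the usual scatter. No measurement at hand offers an explanation for this lack of difference.

Ethyl is the only group seen on this oxygen, so it remains open whether a longer chain such as butyl would behave the same way, or whether an amide in place of the ester would keep the number where it stands. From the compounds shown here alone, it is also open whether ethoxycarbonyl would make as little difference on the methyl-bearing core of compound 2 or the 1,3-benzothiazol-2-yl-bearing core of compound 3, whose numbers lie well below that of compound 1.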